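This account rests on a few compounds, and the source may have more. Where it says the series, first, only, none or still open, it means among the compounds named here.

Values measured in a toxicity assay on KB cells (Homo sapiens) for cytotoxicity, read by fluorescence, with a stated time of 3 days; on this read-out higher numbers stand for an effect only at larger amounts of compound and lower numbers for an effect already at smaller amounts:

- compound 1 `CCCCOC(=O)CNC(=O)[C@H](CSc1ccc([N+](=O)[O-])cc1[N+](=O)[O-])NC(=O)CC[C@H](NC(=O)C(C)(C)C)C(=O)OCCCC`: 83.4 uM
- compound 2 `CCCCOC(=O)CNC(=O)[C@H](CSc1ccc([N+](=O)[O-])cc1[N+](=O)[O-])NC(=O)CC[C@H](Nc1nc(N)nc(Cl)n1)C(=O)OCCCC`: > 300 uM
- compound 3 `CCCCOC(=O)CNC(=O)[C@H](CSc1ccc([N+](=O)[O-])cc1[N+](=O)[O-])NC(=O)CC[C@H](NC(=O)/C=C/c1ccccc1)C(=O)OCCCC`: 34.4 uM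

The entry for compound 2 is a limit of this assay, not a number. Of the two true numbers, compound 3 has the lower, and compound 1 is its nearest neighbour.

In compound 4 `CCCCOC(=O)CNC(=O)[C@H](CSc1ccc([N+](=O)[O-])cc1[N+](=O)[O-])NC(=O)CC[C@H](Nc1ccc([N+](=O)[O-])cc1[N+](=O)[O-])C(=O)OCCCC`, 2,4-dinitrophenyl stands in place of (2-phenylethenyl)carbonyl on an amine nitrogen (2,4-dinitrophenyl in place of (2-phenylethenyl)carbonyl on an amine nitrogen). Among the measured compounds shown here, three measured steps bear on this change. The closest is an at least 8.7-fold lower number from compound 2 to compound 3 (0.94 log units; beyond the scatter), which exchanges the same (2-phenylethenyl)carbonyl for 4-amino-6-chloro-1,3,5-triazin-2-yl at the same place, though read in the opposite direction. A second step, an at least 3.5-fold higher number from compound 1 to compound 2 (0.55 log units; beyond the scatter), brings in that same triazinyl group in place of (tert-butyl)carbonyl and also runs towards a higher number. The third, a 2.4-fold lower number from compound 1 to compound 3 (0.38 log units; beyond the scatter), only swaps one carbonyl group for another and stays modest. Both steps that replace a carbonyl group with a ring on this nitrogen thus point upward, but they rest on compound 2 alone, and its group differs from 2,4-dinitrophenyl. A higher number is therefore expected, though a smaller rise than compound 2 shows. The expected change is a 2.0-fold higher number from compound 3 to compound 4 (0.31 log units; beyond the scatter). For compound 4 the estimated value is 70 uM, with an expected range from 18 uM to 270 uM.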

Compound 4, concentration for half-maximal effect: > 300 uM
Compound 4 was reported as a limit; the forecaster's own chance of this, stated with the estimate: 20%; middle value at least 4.2-fold (0.63 log units) from the limit.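

In this assay compound 4 is given as > 300 uM, which is a limit of the assay and not a number. On this amine nitrogen, 2,4-dinitrophenyl gives an at least 8.7-fold higher number from compound 3 to compound 4 (0.94 log units; beyond the scatter) and an at least 3.5-fold higher number from compound 1 to compound 4 (0.55 log units; beyond the scatter), so the rise from a carbonyl group to an aromatic ring no longer rests on the triazinyl group of compound 2 alone, and none of the four compounds goes against it. The step between compound 2 and compound 4 cannot be read, and the two ring groups cannot be put in order, because both compounds stand at the same ceiling: the limit of > 300 uM in this assay, at which 2 of the 4 values shown sit.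

From the compounds shown here alone, how far compound 2 and compound 4 lie past that limit remains open, so the true size of the rise is unknown and the steps give only its smallest possible size. Going by these compounds, it also remains open whether the rise follows from any aromatic ring placed directly on this nitrogen or only from these two groups, and a plain phenyl group or a benzoyl group at the same place would separate those readings.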